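Three Measured Analogues and an Expected Fourth

A few compounds are considered here, and "the series" means these few. Any claim that something is new, unique, unknown or untested is made for them only; others in the source may bear on it.

Measured so far: compound 1 `O=S(=O)(c1ccccc1)c1nc2ccccc2nc1Nc1ccccc1` gives 590 nM in a functional assay on PC-3 cells (Homo sapiens) for cytotoxicity, read by MTT assay, with a stated time of 72 h; a higher number here means a weaker inhibitor, a lower number a stronger inhibitor; compound 2 `O=S(=O)(c1ccccc1)c1nc2ccccc2nc1Nc1ccc(C(F)(F)F)cc1` gives 3550 nM; compound 3 `Cc1ccc(S(=O)(=O)c2nc3ccccc3nc2Nc2ccccc2)cc1` gives 1060 nM.

Compound 3 stands second highest of these three numbers. Its nearest neighbour is compound 1, within the scatter, and compound 2 lies furthest from it, beyond the scatter. Compound 4 `COc1cc(Nc2nc3ccccc3nc2S(=O)(=O)c2ccc(C)cc2)cc(OC)c1` differs from compound 3 by 3,5-dimethoxyphenyl in place of phenyl on a nitrogen on an aromatic ring. Among the measured compounds shown here, the one measured step that alters the ring on that nitrogen is a 6.0-fold higher number from compound 1 to compound 2 (0.78 log units; beyond the scatter), where a substituent on that ring raised the number. The step of a 1.8-fold higher number from compound 1 to compound 3 (0.25 log units; within the scatter) concerns the other ring and falls within the scatter. On that comparison compound 4 is expected to show a higher number in this assay, roughly a 2.8-fold higher number from compound 3 to compound 4 (0.45 log units; beyond the scatter). The estimate for compound 4 is 3000 nM, with a range from 1000 nM to 10000 nM.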

Compound 4, half-maximal inhibitory concentration: 2940 nM
For compound 4 the middle estimate is 1.0-fold (0.01 log units) above the measured one, within the range that was stated.
By their numbers in this assay, from the lowest: compounds 1 and 3 (each within the scatter of the next); then compounds 4 and 2 (each within the scatter of the next).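

In this assay, putting 3,5-dimethoxyphenyl in place of phenyl on the nitrogen gives a 2.8-fold higher number from compound 3 to compound 4 (0.44 log units; beyond the scatter). Among the compounds shown here, until now the only change to this ring was the trifluoromethyl step, a 6.0-fold higher number from compound 1 to compound 2 (0.78 log units; beyond the scatter); compound 4 shows that a second, different substituted ring also raises the number, and that this holds with the methyl-bearing ring of compound 3 elsewhere in the molecule. No measurement shown here accounts for the rise.

The compounds shown leave open whether an amine or a carboxylic acid on this ring would also raise the number. They also leave open whether any group here would lower it.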